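The compounds below may be only part of what the source reports. "The series", "measured", "known", "first", "only" and "open" are said of these compounds alone.

The three compounds measured share one core. Compound 1 `CCNC(=O)c1nc(-c2cc(OC)c(OC)c(OC)c2)n(-c2ccc(OC)cc2)n1` carries an ethyl group on the amide nitrogen; in a functional assay on the whole organism for inhibition, with Rattus norvegicus as the target, read by paw edema, with stated times of 30 min and 3 h, at a dose of 0.28 mmol/kg by the oral route (a higher number here means more inhibition at the dose given (going by the name of the read-out), a lower number less inhibition), compound 1 gives 88%. Compound 2 `COc1ccc(NC(=O)c2nc(-c3cc(OC)c(OC)c(OC)c3)n(-c3ccc(OC)cc3)n2)cc1` carries a 4-methoxyphenyl group there instead, and in this assay compound 2 gives 86%. Compound 3 `COc1ccc(-n2nc(C(=O)Nc3ccc(C(=O)O)cc3)nc2-c2cc(OC)c(OC)c(OC)c2)cc1` carries a 4-carboxyphenyl group, and in this assay compound 3 gives 95%. Where compound 2 stands among these three numbers is told by its neighbours: the step of a number 2 percentage points lower from compound 1 to compound 2 (within the scatter) and the step of a number 9 percentage points higher from compound 2 to compound 3 (within the scatter) both keep it apart from the others only by amounts inside the scatter, as does the step of a number 7 percentage points higher from compound 1 to compound 3 (within the scatter) between the other two.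

Compound 4 `COc1ccc(-n2nc(C(=O)Nc3ccc(O)cc3)nc2-c2cc(OC)c(OC)c(OC)c2)cc1` is the next variation on compound 2. The change is hydrogen in place of methyl on an oxygen on an aromatic ring. The step that bears on it most directly is the exchange of the same methoxy for carboxy, the step from compound 2 to compound 3, which stayed inside the scatter; the exchanges on the amide nitrogen from compound 1 likewise stayed inside it. Among the measured compounds shown here, no step measured so far has moved this assay beyond its scatter, so the expected step of a number 1 percentage points higher from compound 2 to compound 4 (within the scatter) is also none beyond the scatter. Compound 4 is therefore estimated at 87%, within the range 75% to 96%.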

Compound 4, a percentage reported as inhibition, in the whole organism at one dose (the size of the read-out at that dose, not a potency): 64%
For compound 4 the middle estimate is 23 percentage points above the measured one; measured number outside the range, below it.
By their numbers in this assay, from the lowest: compound 4; then compounds 2, 1 and 3 (each within the scatter of the next).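

In this assay, among the compounds shown here, the exchange of 4-methoxyphenyl for 4-hydroxyphenyl gave the first step beyond the scatter, a number 22 percentage points lower from compound 2 to compound 4 (beyond the scatter), so the group on this aromatic carbon can matter, although methoxy and carboxy had not been told apart there. Hydroxy also separated from carboxy on the same carbon, a number 31 percentage points lower from compound 3 to compound 4 (beyond the scatter), and 4-hydroxyphenyl separated from ethyl on the amide-type nitrogen, a number 24 percentage points lower from compound 1 to compound 4 (beyond the scatter), leaving compound 4 alone below the other three compounds, which remain within the scatter of one another. Nothing available gives an explanation for this fall.

The compounds shown leave open whether the fall is specific to hydroxy or would also appear with an amine or a fluorine on that aromatic carbon, and whether a hydroxy carried on a longer chain in place of ethyl on the amide nitrogen would behave the same way. Since this assay reports inhibition at a single dose, they also leave open whether the gap would persist at other doses.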